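Replacing 3-nitrophenyl with 2-chlorophenyl in the series

The source may hold more compounds than are shown below. What is called first, only, known or untested is meant among the compounds shown, and "the series" means these compounds.

Readings in a functional assay on HCT-116 cells (Homo sapiens) for antiproliferative activity, read by MTT assay; on this read-out higher numbers stand for weaker inhibition and lower numbers for stronger inhibition
- compound 1 `Cn1c(=O)c(=O)n(C2CCCC2)c2nc(N/N=C/c3ccc(S(C)(=O)=O)cc3)ncc21` gives 86600 nM
- compound 2 `Cn1c(=O)c(=O)n(C2CCCC2)c2nc(N/N=C/c3cccs3)ncc21` gives 52600 nM
- compound 3 `Cn1c(=O)c(=O)n(C2CCCC2)c2nc(N/N=C/c3cccc([N+](=O)[O-])c3)ncc21` gives 15200 nM

Compound 3 stands lowest of the three in this assay and both its steps are beyond the scatter. Compound 4 `Cn1c(=O)c(=O)n(C2CCCC2)c2nc(N/N=C/c3ccccc3Cl)ncc21` has 2-chlorophenyl in place of 3-nitrophenyl on a carbon with a double bond to nitrogen. Among the compounds with values here, three measured steps bear on this place. Two are modest: a 5.7-fold lower number from compound 1 to compound 3 (0.76 log units; beyond the scatter) and a 3.5-fold lower number from compound 2 to compound 3 (0.54 log units; beyond the scatter). The third stays within the scatter: a 1.6-fold lower number from compound 1 to compound 2 (0.22 log units; within the scatter). Within the data shown here, no measured compound carries 2-chlorophenyl. A step toward a higher number is expected, a 2.0-fold higher number from compound 3 to compound 4 (0.30 log units; within the scatter) and no larger than the modest steps. For compound 4 the estimate is 30000 nM with an expected range of 11000 nM to 85000 nM.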

Compound 4, half-maximal inhibitory concentration: 14000 nM
Compound 4: the middle estimate sits 2.1-fold (0.33 log units) above what was measured, within the range that was stated.
By their numbers in this assay, from the lowest: compounds 4 and 3 (each within the scatter of the next); then compounds 2 and 1 (each within the scatter of the next).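

In this assay, 2-chlorophenyl on this carbon reads alike with 3-nitrophenyl, with a 1.1-fold lower number from compound 3 to compound 4 (0.04 log units; within the scatter), so hydrogen-bond acceptors on this group are not required to hold the reading of compound 3. The separation from the other two groups also holds with a second substituted phenyl, with a 3.8-fold lower number from compound 2 to compound 4 (0.57 log units; beyond the scatter) and a 6.2-fold lower number from compound 1 to compound 4 (0.79 log units; beyond the scatter). No supporting data bear on why these groups read as they do. Open, on these data alone, is whether unsubstituted phenyl, 4-chlorophenyl or an aminophenyl on this carbon would keep this reading.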